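A few compounds are considered here, and "the series" means these few. Any claim that something is new, unique, unknown or untested is made for them only; others in the source may bear on it.

Measured so far in an ADME assay for permeability, using PAMPA, at pH 7.4; a higher number here means that the compound crosses the layer faster, a lower number that the compound crosses the layer more slowly:
compound 1, `CC(=O)c1ccc(NC(=O)Nc2cc(C)nc3ccccc23)cc1`, gives 473 10^-6 cm/s
compound 2, `Cc1cc(NC(=O)Nc2ccc(F)cc2F)c2ccccc2n1`, gives 640 10^-6 cm/s
compound 3, `COc1ccc(NC(=O)Nc2cc(C)nc3ccccc23)cc1OC`, gives 552 10^-6 cm/s

These three numbers sit close together. The gap from compound 1 to compound 3 and the gap from compound 1 to compound 2 both lie within the usual scatter of repeated measurements, so compound 1 cannot be told apart from the other two in this assay.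

Compound 4, `CCc1ccc(NC(=O)Nc2cc(C)nc3ccccc23)cc1`, has not yet been measured. It differs from compound 1 in one place: ethyl in place of acetyl on an aromatic carbon. The acetyl leaves and an ethyl enters on the same aromatic carbon. Going by the values given here, no measured pair shows this exact change, so its effect cannot be read from the data. Given how close the three known values are, no step beyond the scatter is expected, with a slight lean toward a higher number. For compound 4 the estimate is 560 10^-6 cm/s, with a range from 350 10^-6 cm/s to 850 10^-6 cm/s. The expected step is then a 1.2-fold higher number from compound 1 to compound 4 (0.07 log units; within the scatter).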

Compound 4, apparent permeability: 535 10^-6 cm/s
Estimate against measurement, compound 4: 1.0-fold (0.02 log units) above; low and high end bracket the measured number.
By their numbers in this assay, from the lowest: compounds 1, 4, 3 and 2 (each within the scatter of the next).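

Ethyl in place of acetyl on this aromatic carbon gives a 1.1-fold higher number from compound 1 to compound 4 (0.05 log units; within the scatter) in this assay. This is the first pair shown that differs in one place, and it shows that at this carbon, para to a large group, replacing acetyl with ethyl, and so removing the hydrogen-bond acceptor counted for acetyl, gives no step beyond the scatter. No measurement at hand offers an explanation for this result. As far as these compounds go, it remains open whether an amine, a carboxylic acid or a longer chain on this same carbon would also stay within the scatter.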